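The compounds below may be only part of what the source reports. "The series", "measured", "known", "first", "only" and "open" are said of these compounds alone.

Compound 1 `Cc1ccc(C(=O)OC2(C(=O)Nc3ccc([N+](=O)[O-])cc3)CCCCC2)cc1` and compound 2 `O=C(OC1(C(=O)Nc2ccc([N+](=O)[O-])cc2)CCCCC1)c1ccc(Br)cc1` share one core and differ only in the group on the outer aromatic ring. In an ADME assay on WI-38 cells (Homo sapiens) for inhibition, read by MTT assay, with a stated time of 72 h (a lower number here means a stronger inhibitor, a higher number a weaker inhibitor), compound 1 gives 32 nM, while compound 2 gives 523 nM, the higher of the two numbers, so compound 2 is the weaker inhibitor here. For the measured compounds named here, the single measured step is a 16-fold higher number from compound 1 to compound 2 (1.21 log units; beyond the scatter). Compound 3 `O=C(OC1(C(=O)Nc2ccc([N+](=O)[O-])cc2)CCCCC1)c1ccc([N+](=O)[O-])cc1` carries the change (nitro in place of bromo on an aromatic carbon). Going by the values given here, no measured pair shows this exact swap, so the one known step bears on it only loosely. A change within the scatter is therefore expected, namely a 1.1-fold higher number from compound 2 to compound 3 (0.06 log units; within the scatter). For compound 3 the estimate is 600 nM, with a range from 150 nM to 3000 nM.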

Compound 3, half-maximal inhibitory concentration: 761 nM
Compound 3: the middle estimate sits 1.3-fold (0.10 log units) below what was measured; the range from low to high includes it.
By their numbers in this assay, from the lowest: compound 1; then compounds 2 and 3 (each within the scatter of the next).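

In this assay, putting nitro in place of bromo at this position changes little (a 1.5-fold higher number from compound 2 to compound 3 (0.16 log units; within the scatter)), so these two groups cannot be told apart here. Nitro in place of methyl gives a large step (a 24-fold higher number from compound 1 to compound 3 (1.38 log units; beyond the scatter)), so among these three compounds, methyl alone stands apart from the other two groups. Nothing available explains this difference. Going by these compounds, it remains open whether an amine or a carboxylic acid at this position would match methyl or fall with bromo and nitro. On these data alone, whether a longer chain, such as ethyl, would match methyl is also open.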